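The source may hold more compounds than are shown below. What is called first, only, known or untested is meant among the compounds shown, and "the series" means these compounds.

Measured compounds in a physicochemical assay for solubility, read by HPLC, with a stated time of 24 h; on this read-out higher numbers stand for higher solubility and lower numbers for lower solubility:
compound 1 `CCN1CCN(C[C@H]2CN(c3ccc(-n4cc(-c5ccccn5)cn4)c(F)c3)C(=O)O2)CC1`: 706000 nM
compound 2 `COC(=O)CC1CCN(C[C@H]2CN(c3ccc(-n4cc(-c5ccccn5)cn4)c(F)c3)C(=O)O2)CC1`: 92100 nM
compound 3 `CS(=O)(=O)NC[C@H]1CN(c2ccc(-n3cc(-c4ccccn4)cn3)c(F)c2)C(=O)O1`: 2300 nM

Compound 3 stands lowest of the three in this assay. Each step that reaches it is beyond the scatter: a 310-fold lower number from compound 1 to compound 3 (2.49 log units; beyond the scatter) and a 40-fold lower number from compound 2 to compound 3 (1.60 log units; beyond the scatter). Between the other two, a 7.7-fold lower number from compound 1 to compound 2 (0.88 log units; beyond the scatter) is the smaller step.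

Compound 4 `CCNC(=O)NC[C@H]1CN(c2ccc(-n3cc(-c4ccccn4)cn3)c(F)c2)C(=O)O1` differs from compound 3 by ethylcarbamoyl in place of methylsulfonyl on an amine nitrogen. Neither measured step bears directly on this change: both replaced a ring amine on the saturated chain carbon with the methanesulfonamido group, and none alters the substituent on that amine nitrogen. There is thus no measured basis for a step beyond the scatter, and compound 4 is expected to sit near compound 3, a 1.1-fold higher number from compound 3 to compound 4 (0.04 log units; within the scatter). The estimate for compound 4 is 2500 nM, with a range from 700 nM to 9000 nM.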

Compound 4, solubility: 222000 nM
Beside the measured number, compound 4's estimate is 89-fold (1.95 log units) below it; measured number above the stated range.
By their numbers in this assay, from the lowest: compound 3; then compound 2; then compound 4; then compound 1.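

In this assay, among the compounds shown here, the group on the amine nitrogen proves to matter, where the earlier compounds left it untested: ethylcarbamoyl in place of methylsulfonyl gives a 97-fold higher number from compound 3 to compound 4 (1.98 log units; beyond the scatter). The other steps place this (ethylcarbamoyl)amino group among the ring amines, with a 2.4-fold higher number from compound 2 to compound 4 (0.38 log units; beyond the scatter) and a 3.2-fold lower number from compound 1 to compound 4 (0.50 log units; beyond the scatter). No measurement in hand accounts for the large step.

Open, from the compounds shown here alone, is whether a longer chain on the carbamoyl, or an acetyl group on the same amine nitrogen, keeps the number near compound 4 or returns it toward compound 3.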